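This account rests on a few compounds, and the source may have more. Where it says the series, first, only, none or still open, it means among the compounds named here.

Measured so far:
compound 1 `CC1CCN(c2cccc(Nc3nccc(-c4cccs4)n3)c2)CC1` — 3500 nM
compound 2 `CN(C)c1cccc(Nc2nccc(-c3cccs3)n2)c1` — 2400 nM

In a functional assay for inhibition, with Homo sapiens as the target (a higher number here means a weaker inhibitor, a lower number a stronger inhibitor), compound 1 gives 3500 nM. Within the data shown here, its only measured neighbour is compound 2, and a 1.5-fold lower number from compound 1 to compound 2 (0.16 log units; within the scatter), so the two numbers cannot be told apart. Compound 3 `CC1CCN(c2cccc(Nc3nccc(-c4cccnc4)n3)c2)CC1` has not been measured. It differs from compound 1 in one place: pyridin-3-yl in place of thiophen-2-yl on an aromatic carbon. Among the measured compounds shown here, the single measured step changes a different part of the molecule and leaves thiophen-2-yl untouched, so no measured step bears on this change, and no direction beyond the scatter can be expected. The step is estimated as a 1.1-fold higher number from compound 1 to compound 3 (0.06 log units; within the scatter). Compound 3 is therefore expected at 4000 nM, with a range from 1500 nM to 12000 nM.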

Compound 3, half-maximal inhibitory concentration: 1200 nM
Compound 3: the middle estimate sits 3.3-fold (0.52 log units) above what was measured, and the stated range ends above it.
By their numbers in this assay, from the lowest: compounds 3, 2 and 1 (each within the scatter of the next, the first and the last beyond it).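

In this assay, the ring at this position does shift the number: pyridin-3-yl in place of thiophen-2-yl gives a 2.9-fold lower number from compound 1 to compound 3 (0.46 log units; beyond the scatter). This is the only step among these compounds that lies beyond the scatter, as the earlier change from 4-methylpiperidin-1-yl to dimethylamino did not. Nothing measured here explains why this swap has an effect.

Going by these compounds, it remains open whether phenyl, a ring with no hetero atom, or pyridin-4-yl would behave like pyridin-3-yl. On these data alone, it is also open whether the same swap on compound 2 would give a similar step.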